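A Bromine for a Fluorine at the Detection Limit

The source may report more compounds than this note shows. Statements on the series, on what has been measured and on what is new or still open speak of the compounds shown alone.

Compound 3 `CCC(COc1cccc(F)c1)OC(=O)NCc1ccccc1` carries a fluoro group on its outer aromatic ring. In an assay for inhibition of zeta-carotene desaturase, chloroplastic/chromoplastic (Capsicum annuum), using a Dixon plot, with a stated time of 8 h (on this read-out lower numbers stand for stronger inhibition and higher numbers for weaker inhibition), compound 3 gives > 100000 nM, which is a limit of the assay and not a number. Compound 1 `CCC(COc1cccc(C(F)(F)F)c1)OC(=O)NCc1ccccc1` gives > 100000 nM in this assay, again a limit. Compound 2 `CCC(COc1ccccc1Cl)OC(=O)NCc1ccccc1` gives > 100000 nM in this assay, also a limit. Because all three values sit at the limit of > 100000 nM in this assay, at which 3 of the 3 values shown sit, the steps a step that the two limits leave unreadable from compound 1 to compound 3 and a step that the two limits leave unreadable from compound 2 to compound 3 cannot be read. Compound 4 `CCC(COc1cccc(Br)c1)OC(=O)NCc1ccccc1` differs from compound 3 by bromo in place of fluoro on an aromatic carbon. Among the measured compounds shown here, no measured step bears on this change, so no movement beyond the scatter is expected. Compound 4 is therefore expected to give about 150000 nM in this assay, within 30000 nM to 1000000 nM, most probably again only a limit. This corresponds to an expected step that the limit leaves unreadable from compound 3 to compound 4.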

Compound 4, half-maximal inhibitory concentration: > 100000 nM
Compound 4 was reported as a limit; the forecaster's own chance of this, stated with the estimate: 85%; the middle value does not contradict the limit.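

Compound 4 is again only a limit, so its steps from compound 1, compound 2 and compound 3 cannot be read: the limit of > 100000 nM in this assay, at which 4 of the 4 values shown sit.

The compounds shown leave open whether any group on the outer aromatic ring gives a readable value in this assay and how far apart these four compounds truly lie.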